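A Methyl Added to Compound 2: Expected Inhibition

The source may hold more compounds than are shown below. What is called first, only, known or untested is meant among the compounds shown, and "the series" means these compounds.

In a functional assay on the whole organism (6C3HED cells, Mus musculus) for inhibition, at a dose of 300 mg/kg by the oral route (a higher number here means more inhibition at the dose given (going by the name of the read-out), a lower number less inhibition), three compounds have been measured so far:
Compound 1 `O=C(Nc1ccc(Cl)cc1)NS(=O)(=O)c1cccs1` gives 66%
Compound 2 `CCc1ccc(S(=O)(=O)NC(=O)Nc2ccc(Cl)cc2)s1` gives 89%
Compound 3 `COc1csc(S(=O)(=O)NC(=O)Nc2ccc(Cl)cc2)c1` gives 69%

Compound 2 stands highest of the three: a number 20 percentage points lower from compound 2 to compound 3 (beyond the scatter) and a number 23 percentage points higher from compound 1 to compound 2 (beyond the scatter). Compound 4 `CCc1sc(S(=O)(=O)NC(=O)Nc2ccc(Cl)cc2)cc1C` differs from compound 2 in one place: methyl in place of hydrogen on an aromatic carbon. The closest guide is the step of a number 23 percentage points higher from compound 1 to compound 2 (beyond the scatter), in which a small alkyl group also entered on an aromatic carbon; yet the step of a number 3 percentage points higher from compound 1 to compound 3 (within the scatter) shows that an added group need not move the number at all. Since compound 2 already lies near the top of the scale, little room for a further rise remains. The step from compound 2 to compound 4 is therefore expected to be a number 1 percentage points lower from compound 2 to compound 4 (within the scatter), none beyond the scatter. Compound 4 is estimated at 88%, within a range from 72% to 98%.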

Compound 4, a percentage reported as inhibition, in the whole organism at one dose (the size of the read-out at that dose, not a potency): 58%
Estimate against measurement, compound 4: 30 percentage points above; measured number outside the range, below it.
By their numbers in this assay, from the lowest: compounds 4, 1 and 3 (each within the scatter of the next, the first and the last beyond it); then compound 2.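

Placing a methyl on this aromatic carbon, next to the ring atom that bears an ethyl group, gives in this assay a number that changes sharply: a number 31 percentage points lower from compound 2 to compound 4 (beyond the scatter). A small alkyl group on an aromatic carbon therefore does not always raise the number, whereas ethyl gave a number 23 percentage points higher from compound 1 to compound 2 (beyond the scatter). Nothing measured here says why the number falls.

Open, from the compounds shown here alone, is whether a fluorine, an amine or a longer chain at this same place would lower the number as well. Also open, going by these compounds, is whether the methyl would have the same effect without the neighbouring ethyl group.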